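A few compounds are considered here, and "the series" means these few. Any claim that something is new, unique, unknown or untested is made for them only; others in the source may bear on it.

Working notes on the series. Among the measured compounds shown here, compound 2 `N#Cc1cccc(-n2cc(COc3cccc(NC(=O)Nc4ccc(Cl)c(C(F)(F)F)c4)c3)nn2)c1` gives 2760 nM in a functional assay on HepG2 cells (Homo sapiens) for inhibition, read by MTT assay, with a stated time of 72 h (a lower number here means a stronger inhibitor, a higher number a weaker inhibitor), the highest of the two numbers so far; the nearest is compound 1 `COc1cccc(-n2cc(COc3cccc(NC(=O)Nc4ccc(Cl)c(C(F)(F)F)c4)c3)nn2)c1`, which gives 1310 nM. For the measured compounds named here, the only step recorded between them is a 2.1-fold higher number from compound 1 to compound 2 (0.32 log units; beyond the scatter), a modest shift that is still beyond the scatter. Compound 3 `CCc1ccc(-n2cc(COc3cccc(NC(=O)Nc4ccc(Cl)c(C(F)(F)F)c4)c3)nn2)cc1` is not yet measured; it differs from compound 2 by 4-ethylphenyl in place of 3-cyanophenyl on an aromatic nitrogen. Going by the values given here, no measured step covers this exact exchange, since the one step known swaps substituents on the same ring rather than moving to an ethyl group, so the direction of the change can only be read loosely from the fact that compound 2 stands at the weaker end of the pair. The expectation is therefore a moderate step of a 1.8-fold lower number from compound 2 to compound 3 (0.26 log units; within the scatter), toward a lower number, though a result within the scatter of compound 2 would not be surprising. Compound 3 is estimated at 1500 nM, with a range from 600 nM to 4000 nM.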

Compound 3, half-maximal inhibitory concentration: 1950 nM
Beside the measured number, compound 3's estimate is 1.3-fold (0.11 log units) below it, and the stated range covers the measured number.
By their numbers in this assay, from the lowest: compounds 1, 3 and 2 (each within the scatter of the next, the first and the last beyond it).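

In this assay, the aryl group on the aromatic nitrogen changes without a clear shift in either listed step: a 1.4-fold lower number from compound 2 to compound 3 (0.15 log units; within the scatter) and a 1.5-fold higher number from compound 1 to compound 3 (0.17 log units; within the scatter). The 4-ethylphenyl group has no hydrogen-bond acceptor, unlike 3-cyanophenyl, yet compound 3 cannot be separated from compound 2 or compound 1, even though those two lie beyond the scatter of each other. Nothing measured here explains these numbers.

Each exchange changes both the group and its ring position, so the two contributions cannot be told apart in these compounds. From the compounds shown here alone, whether an amine, a carboxylic acid or a chain longer than ethyl on this phenyl ring would give a step beyond the scatter stays open.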